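Triazole aryl swap on a bridged phenol series

The source may report more compounds than this note shows. Statements on the series, on what has been measured and on what is new or still open speak of the compounds shown alone.

Compound 1 `C=C1C[C@]23C[C@@]1(O)CC[C@H]2c1cc(Br)c(O)c(C)c1[C@@H]3Cn1cc(-c2ccccn2)nn1` gives in a functional assay on SMMC-7721 cells (Homo sapiens) for cytotoxicity, read by MTT assay, with a stated time of 4 days (a higher number here means a weaker inhibitor, a lower number a stronger inhibitor), only a limit, > 20000 nM.
Compound 2 `C=C1C[C@]23C[C@@]1(O)CC[C@H]2c1ccc(O)c(C)c1[C@@H]3Cn1cc(-c2ccccn2)nn1` gives in this assay only a limit, > 20000 nM.
Compound 3 `C=C1C[C@]23C[C@@]1(O)CC[C@H]2c1ccc(OS(=O)(=O)c2ccc(C)cc2)c(C)c1[C@@H]3Cn1cc(-c2ccccn2)nn1` gives in this assay only a limit, > 20000 nM.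

Compound 2 thus stands at a limit of the assay rather than at a number, and the two neighbours shown sit at the same limit (the limit of > 20000 nM in this assay, at which 3 of the 3 values shown sit). The step that the two limits leave unreadable from compound 1 to compound 2 is unreadable, and the step that the two limits leave unreadable from compound 2 to compound 3 is unreadable as well; neither can give a size or a direction.

Compound 4 `C=C1C[C@]23C[C@@]1(O)CC[C@H]2c1ccc(O)c(C)c1[C@@H]3Cn1cc(-c2ccc(Br)cc2)nn1` is not yet measured. It differs from compound 2 in one place: 4-bromophenyl in place of pyridin-2-yl on an aromatic carbon. Among the compounds with values here, no measured step touches that position, so nothing among the three values says how a change there would move the read-out.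

With every neighbour at the limit, compound 4 is expected to remain at or near that limit, a step that the limit leaves unreadable from compound 2 to compound 4 in this assay that cannot be separated from the scatter. Compound 4 is estimated at 30000 nM, within 10000 nM to 100000 nM.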

Compound 4, half-maximal inhibitory concentration: > 20000 nM
Compound 4 was reported as a limit (the forecaster's own chance of this, stated with the estimate: 80%); the middle value does not contradict the limit.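

Compound 4 gives only a limit in this assay, > 20000 nM. Compound 2 is also a limit, so no step can be read between compound 2 and compound 4: the limit of > 20000 nM in this assay, at which 4 of the 4 values shown sit.

The compounds shown leave open how strongly any of them acts in this assay, since none gives a number.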